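The compounds below may be only part of what the source reports. "The series", "measured", "known", "first", "only" and "open" are said of these compounds alone.

Of the compounds shown here, two of the shared core have been measured in a functional assay on HCT-116 cells (Homo sapiens) for inhibition, read by MTT assay, with a stated time of 48 h, tested at 1 mg/mL; on this read-out lower numbers stand for less inhibition and higher numbers for more inhibition at the one concentration tested (going by the name of the read-out). Compound 1 `N#CC1=C(N)N2C(=O)CSC2=C(C#N)C1c1ccc(F)cc1` gives 47.8% in this assay, and compound 2 `N#CC1=C(N)N2C(=O)CSC2=C(C#N)C1c1ccccc1Cl` gives 54.1%. Compound 2 stands highest of the two numbers, with compound 1 nearest at a number 6.3 percentage points higher from compound 1 to compound 2 (within the scatter); the two are therefore not separated beyond the scatter. The next compound, compound 3 `N#CC1=C(N)N2C(=O)CSC2=C(C#N)C1c1ccc(Cl)cc1Cl`, differs from compound 2 by chloro in place of hydrogen on an aromatic carbon. Among the compounds with values here, the only measured step, from a 4-fluorophenyl to a 2-chlorophenyl on the saturated ring carbon, bears on the phenyl substituent as well but not on a second chloro added to an already chlorinated ring, and it was within the scatter. A step of similar small size is expected here, a number 1.9 percentage points higher from compound 2 to compound 3 (within the scatter), without a direction that can be read from the numbers. Compound 3 is estimated at 56% in this assay, between 40% and 72%.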

Compound 3, a percentage reported as inhibition, at one concentration (the size of the read-out at that concentration, not a potency): 29.9%
For compound 3 the middle estimate is 26.1 percentage points above the measured one, outside the stated range (below it).
By their numbers in this assay, from the lowest: compound 3; then compounds 1 and 2 (each within the scatter of the next).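

In this assay, chloro in place of hydrogen on an aromatic carbon, meta to a chloro group and para to a large group, gives a number 24.2 percentage points lower from compound 2 to compound 3 (beyond the scatter). Within the data shown here, this is the first step to lie beyond the scatter, whereas a number 6.3 percentage points higher from compound 1 to compound 2 (within the scatter) left those two compounds unseparated, so a single added chloro at this position is enough to shift the read-out at the one concentration tested. Nothing at hand accounts for the size or direction of this step.

Going by these compounds, whether a methoxy group or an amine on the same aromatic carbon would lower the number as well remains open, so the step cannot yet be assigned to the position or to chloro itself. Also open, on these data alone, is how a chloro at this position would behave without the chloro group already on the ring.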